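Acetyl in place of trifluoromethyl: expecting compound 3

The compounds below may be only part of what the source reports. "The series", "measured", "known", "first", "only" and "open" are said of these compounds alone.

Compound 1 `COc1ccc(-c2c(C)nc3c(N4CC[C@@H](NC(=O)C(F)(F)F)C4)cc(C)nn23)cc1OC` with > 95%
Compound 2 `COc1ccc(-c2c(C)nc3c(N4CC[C@@H](NS(=O)(=O)c5ccc(C(F)(F)F)cc5)C4)cc(C)nn23)cc1OC` with > 95%

In an ADME assay on microsomes from liver (Homo sapiens) for metabolic stability, read by LC-MS, with NADPH named in the record, with a stated time of 60 min, tested at 1 uM, in the absence of a further agent (a lower number here means that less of the compound is left, a higher number that more of the compound is left), compound 1 gives > 95%, which is a limit of the assay and not a number. Compound 2 stands at > 95%, and this too is only a limit. Going by the values given here, the series so far therefore offers the limit of > 95% in this assay, at which 2 of the 2 values shown sit, and no exact figure.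

Compound 3 `COc1ccc(-c2c(C)nc3c(N4CC[C@@H](NS(=O)(=O)c5ccc(C(C)=O)cc5)C4)cc(C)nn23)cc1OC` carries acetyl in place of trifluoromethyl on an aromatic carbon, para to a large group (acetyl in place of trifluoromethyl on an aromatic carbon). Among the compounds with values here, no measured step shows what this swap does, so compound 2 at its limit of > 95% is the only guide. A small downward step is expected in this assay, estimated as a number at least 5 percentage points lower from compound 2 to compound 3 (that floor lies within the scatter), and it may not exceed the usual scatter. For compound 3 the expected value is 90%, with an estimated range from 72% to 100%.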

Compound 3, percent of the compound remaining: > 95%
Compound 3 ended at the assay's limit; the forecaster's own chance of this, stated with the estimate: 40%; at least 5 percentage points between middle value and limit.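

Going by these compounds alone, no step among compound 1, compound 2 and compound 3 can be read in this assay, since all three stand at the same limit of the assay: the limit of > 95% in this assay, at which 3 of the 3 values shown sit. The compounds shown leave open whether acetyl in place of trifluoromethyl changes the amount of compound remaining at all.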